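The source may report more compounds than this note shows. Statements on the series, on what has been measured and on what is new or still open speak of the compounds shown alone.

Three compounds built on one shared core, differing only in the group carried on the sulfonamide nitrogen, have been tested in a functional assay on MCF7 cells (Homo sapiens) for antiproliferative activity, read by CCK-8 assay, with a stated time of 72 h; on this read-out lower numbers stand for stronger inhibition of growth and higher numbers for weaker inhibition of growth. Compound 1 `CC[C@@H]1C(=O)N(C)c2cnc(Nc3ccc(S(=O)(=O)NCCO)cc3)nc2N1C1CCCC1` carries a 2-hydroxyethyl there and gives 344 nM. Compound 2 `CC[C@@H]1C(=O)N(C)c2cnc(Nc3ccc(S(=O)(=O)NC4CCCC4)cc3)nc2N1C1CCCC1` carries a cyclopentyl and gives 688 nM. Compound 3 `CCCCNS(=O)(=O)c1ccc(Nc2ncc3c(n2)N(C2CCCC2)[C@H](CC)C(=O)N3C)cc1` carries a butyl and gives 459 nM. Compound 3 thus sits second highest of the three numbers, and all three lie within the usual scatter of one another: a 2.0-fold higher number from compound 1 to compound 2 (0.30 log units; within the scatter), a 1.3-fold higher number from compound 1 to compound 3 (0.13 log units; within the scatter), and a 1.5-fold lower number from compound 2 to compound 3 (0.18 log units; within the scatter).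

Compound 4 `CC[C@@H]1C(=O)N(C)c2cnc(Nc3ccc(S(=O)(=O)NCC(C)C)cc3)nc2N1C1CCCC1` is the next member of this set. It differs from compound 3 as follows: isopropyl in place of propyl on a saturated chain carbon bound to a sulfonamide nitrogen. The three measured steps are the ones that bear on this change, since each also swaps the group on the sulfonamide nitrogen, and none of them moved the number beyond the scatter, even when a short hydroxylated chain was traded for a ring or a ring for a straight chain. Rearranging the branching of a chain of the same size is a smaller change than any of those, so no step beyond the scatter is expected in this assay for compound 4, which is estimated at 450 nM, in a range of 200 nM to 1000 nM, amounting to a 1.0-fold lower number from compound 3 to compound 4 (0.01 log units; within the scatter).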

Compound 4, concentration for 50% growth inhibition: 403 nM
For compound 4 the middle estimate is 1.1-fold (0.05 log units) above the measured one; the range from low to high includes it.
By their numbers in this assay, from the lowest: compounds 1, 4, 3 and 2 (each within the scatter of the next).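

Moving the branch within a chain of the same atoms, isopropyl in place of propyl on a saturated chain carbon bound to a sulfonamide nitrogen, gives a 1.1-fold lower number from compound 3 to compound 4 (0.06 log units; within the scatter) in this assay, the first view of a branched chain at this position and of a change that keeps the atoms the same. The branched isobutyl group also stays close to the two other kinds of group tested here, with a 1.7-fold lower number from compound 2 to compound 4 (0.23 log units; within the scatter) against the cyclopentyl group and a 1.2-fold higher number from compound 1 to compound 4 (0.07 log units; within the scatter) against the hydroxyl-bearing chain, and so all four groups on this nitrogen now lie within the scatter of one another. Nothing given here explains these numbers or says what they reflect in the cells.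

The compounds shown leave open whether this nitrogen remains as undemanding with a chain ending in an amine or a carboxylic acid, with a much longer chain such as octyl, or with an aromatic ring such as phenyl. They also leave open whether any group here would behave the same way in cells other than MCF7, or on a core changed elsewhere.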